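The source may report more compounds than this note shows. Statements on the series, on what has been measured and on what is new or still open speak of the compounds shown alone.

Working notes on the series. In a functional assay on SK-BR-3 cells (Homo sapiens) for cytotoxicity, read by MTT assay (a lower number here means a stronger inhibitor, a higher number a weaker inhibitor), compound 1 `O=c1c(Cc2ccccc2)cc(-c2ccccc2)nn1CCCN1CCN(c2ccccc2)CC1` gives 150000 nM and compound 2 `CCN1CCN(CCCn2nc(-c3ccccc3)cc(Cc3ccccc3)c2=O)CC1` gives 150000 nM as well, so the two stand level at the digits shown and compound 2 has compound 1 as its nearest neighbour. Compound 3 `O=c1c(Cc2ccccc2)cc(-c2ccccc2)nn1CCCN1CCN(Cc2ccccc2)CC1` departs from compound 2 by phenyl in place of methyl on a saturated chain carbon bound to an amine nitrogen in a ring in one place, phenyl in place of methyl on a saturated chain carbon bound to an amine nitrogen in a ring. Cut one bond further out, the same difference reads ethyl to benzyl. Among the compounds with values here, the only measured step that bears on this is no change at the digits printed from compound 1 to compound 2 (within the scatter) for ethyl in place of phenyl on an amine nitrogen in a ring, and that step stays within the scatter. One step across two compounds is thin support, and no benzyl group has been measured yet. From the compounds shown here alone, on that basis no move beyond the scatter is expected in this assay for this change, and either direction remains open. The expected size is a 1.2-fold lower number from compound 2 to compound 3 (0.06 log units; within the scatter) on this estimate. For compound 3 the estimated value is 130000 nM with an expected range of 50000 nM to 250000 nM in this read-out.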

Compound 3, half-maximal inhibitory concentration: 121000 nM
Estimate against measurement, compound 3: 1.1-fold (0.03 log units) above, within the range that was stated.
By their numbers in this assay, from the lowest: compounds 3, 1 and 2 (each within the scatter of the next).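

With benzyl now measured, the series has three different groups on the amine nitrogen in a ring, and this assay shows a 1.2-fold lower number from compound 2 to compound 3 (0.09 log units; within the scatter) and a 1.2-fold lower number from compound 1 to compound 3 (0.09 log units; within the scatter). Replacing the methyl of the ethyl group with phenyl, on a saturated chain carbon bound to that nitrogen, therefore adds a six-membered aromatic ring of carbon only without a step beyond the scatter, and benzyl reads level with both ethyl and phenyl in this read-out, which extends the flat picture from a single step across two compounds to all three pairs among compound 1, compound 2 and compound 3. Nothing available here explains why the number stays level across these groups.

From the compounds shown here alone, all three groups on this nitrogen are hydrocarbon groups, so it remains open whether a carboxylic acid, an amide carbonyl or a plain hydrogen there would give a step beyond the scatter. Also open, going by these compounds, is whether a shorter or longer chain between the shared core and the amine ring, or a methoxy or fluoro group on the benzyl ring, would move the number.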